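Carbamate Gives Way to an Aryloxyacetamide on the Ring Amine

The source may report more compounds than this note shows. Statements on the series, on what has been measured and on what is new or still open speak of the compounds shown alone.

Compound 1, `Nc1nc(N2CCN(S(=O)(=O)c3ccccc3)CC2)c2nc(-c3ccc(F)cc3)sc2n1`: in a functional assay on cells (Lymphocyte, Homo sapiens) (a higher number here means a weaker inhibitor, a lower number a stronger inhibitor), it stands at > 10000 nM, a limit of the assay and not a number.
Compound 2, `Nc1nc(N2CCN(C(=O)OCc3ccccc3)CC2)c2nc(-c3ccc(F)cc3)sc2n1`: in this assay compound 2 gives 4900 nM.

Compound 2 thus holds the only number shown; compound 1 stops at a limit, as the limit of > 10000 nM in this assay, at which 1 of the 2 values shown sits, records. Going by the values given here, the single measured step, an at least 2.0-fold lower number from compound 1 to compound 2 (0.30 log units; that floor lies within the scatter), changes the group on the ring amine nitrogen, as does the step to compound 3, `Nc1nc(N2CCN(C(=O)COc3ccc(Br)cc3)CC2)c2nc(-c3ccc(F)cc3)sc2n1`, in which ((4-bromophenoxy)methyl in place of benzyloxy on a carbonyl carbon). Among the compounds with values here, that measured step reaches only its floor, within the scatter, and no measured step touches the benzyloxy itself, so no movement beyond the scatter is expected in this assay. Compound 3 is therefore estimated to give 5000 nM, between 1500 nM and 16000 nM, an expected step of a 1.0-fold higher number from compound 2 to compound 3 (0.01 log units; within the scatter).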

Compound 3, half-maximal inhibitory concentration: 380 nM
Beside the measured number, compound 3's estimate is 13-fold (1.12 log units) above it; the measured number lies below the stated range.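

In this assay, the group on the carbonyl carbon proves able to move the number well beyond the scatter: (4-bromophenoxy)methyl in place of benzyloxy gives a 13-fold lower number from compound 2 to compound 3 (1.11 log units; beyond the scatter). Measured against the phenylsulfonyl group on the ring amine nitrogen, the change is also large, with an at least 26-fold lower number from compound 1 to compound 3 (1.42 log units; beyond the scatter). Compound 1 remains at a limit of the assay and not a number: the limit of > 10000 nM in this assay, at which 1 of the 3 values shown sits.

The single change both adds the bromine and rearranges the chain, and the compounds shown do not separate these two. On these data alone, whether a plain phenoxymethyl, a 4-chlorophenoxymethyl or a longer chain would hold the gain remains open.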